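Exchanging the phenyl group on the core's aromatic nitrogen

The compounds below may be only part of what the source reports. "The series", "measured", "known", "first", "only" and "open" are said of these compounds alone.

Compound 1 `COc1cc2c(Oc3ccc(NC(=O)c4nn(-c5ccccc5C(F)(F)F)c(=O)cc4C)cc3F)ccnc2cc1OCCCN1CCCCC1` and compound 2 `COc1cc2c(Oc3ccc(NC(=O)c4nn(-c5ccccc5OC(F)(F)F)c(=O)cc4C)cc3F)ccnc2cc1OCCCN1CCCCC1` share one core and differ only in the substituent on the phenyl group that sits on the aromatic nitrogen. In a functional assay on NCI-H460 cells (Homo sapiens) for inhibition, read by MTT assay, with a stated time of 72 h (a lower number here means a stronger inhibitor, a higher number a weaker inhibitor), compound 1 gives 210 nM, and compound 2 gives 230 nM. The step of a 1.1-fold higher number from compound 1 to compound 2 (0.04 log units; within the scatter) is within the scatter, so compound 2 carries the higher of the two numbers without being distinguishable from compound 1.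

Compound 3 `COc1cc2c(Oc3ccc(NC(=O)c4nn(-c5cccc(F)c5)c(=O)cc4C)cc3F)ccnc2cc1OCCCN1CCCCC1` has not yet been measured. It differs from compound 2 by 3-fluorophenyl in place of 2-(trifluoromethoxy)phenyl on an aromatic nitrogen. Among the measured compounds shown here, the single measured step, a 1.1-fold higher number from compound 1 to compound 2 (0.04 log units; within the scatter), concerned only a swap of trifluoromethyl for trifluoromethoxy at the same place and stayed within the scatter; no measured step speaks to an exchange of the whole phenyl group for 3-fluorophenyl. The expectation therefore rests on the unchanged shared core. Compound 3 is expected to show a step of a 1.1-fold higher number from compound 2 to compound 3 (0.05 log units; within the scatter) in this assay, likely within the scatter, with an estimated value of 260 nM and a range from 90 nM to 750 nM.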

Compound 3, half-maximal inhibitory concentration: 360 nM
The estimate for compound 3 lay 1.4-fold (0.14 log units) below the measured number; the measured number falls inside the stated range.
By their numbers in this assay, from the lowest: compounds 1, 2 and 3 (each within the scatter of the next).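

Among the compounds shown here, with compound 3, the group on the aromatic nitrogen is exchanged as a whole for the first time, rather than through a swap of one fluorinated substituent for another: 3-fluorophenyl, with 7 heavy atoms, replaces 2-(trifluoromethoxy)phenyl, with 11 heavy atoms. In this assay this gives a 1.6-fold higher number from compound 2 to compound 3 (0.19 log units; within the scatter) and, set against the 2-(trifluoromethyl)phenyl group, a 1.7-fold higher number from compound 1 to compound 3 (0.23 log units; within the scatter) as the second step. Both steps stay within the scatter, so all three groups on this nitrogen give numbers that cannot be told apart, even though the substituent differs in both identity and place on the phenyl group. Nothing at hand accounts for these numbers or for the absence of a clear separation. Because compound 3 changes the substituent and its place together, the compounds shown leave open what each of the two changes contributes alone, as a 2-fluorophenyl or a 3-(trifluoromethyl)phenyl group would show. They also leave open whether a phenyl group carrying an amine or a carboxylic acid, or a plain methyl group on the nitrogen in place of the phenyl group, would move the number beyond the scatter.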